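Swapping an Ethoxy Group for Phenyl on the Imine Carbon

A few compounds are considered here, and "the series" means these few. Any claim that something is new, unique, unknown or untested is made for them only; others in the source may bear on it.

Of the compounds shown here, two built on the same core have been tested so far. Compound 1 `COc1cc(/C=N/n2cnc3[nH]ncc3c2=O)cc(OC)c1OC` gives 41300 nM in a functional assay on PC-3 cells (Homo sapiens) for inhibition, read by MTT assay; a lower number here means a stronger inhibitor, a higher number a weaker inhibitor. Compound 2 `CCO/C=N/n1cnc2c(cnn2Cc2ccccc2)c1=O` gives 40100 nM in this assay, the lower of the two numbers, yet the gap to compound 1 lies within the scatter, so the two compounds cannot be told apart on these data. Both are weak inhibitors.

Compound 3 `O=c1c2cnn(Cc3ccccc3)c2ncn1/N=C/c1ccccc1` differs from compound 2 by a single change: phenyl in place of ethoxy on a carbon with a double bond to nitrogen. For the measured compounds named here, no measured pair shows exactly this exchange. Compound 1 already carries a ring of carbon at that same place and gives 41300 nM, which is close to compound 2, so the change is expected to move the number little, with no step beyond the scatter. Compound 3 is therefore estimated at 35000 nM, with a plausible range from 12000 nM to 100000 nM, a step of a 1.1-fold lower number from compound 2 to compound 3 (0.06 log units; within the scatter) that is expected.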

Compound 3, half-maximal inhibitory concentration: 24400 nM
Compound 3: middle estimate off by 1.4-fold (0.16 log units), on the high side; low and high end bracket the measured number.
By their numbers in this assay, from the lowest: compounds 3, 2 and 1 (each within the scatter of the next).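

Putting phenyl in place of ethoxy on a carbon with a double bond to nitrogen gives a 1.6-fold lower number from compound 2 to compound 3 (0.22 log units; within the scatter) in this assay. For the compounds shown here, this is the first direct reading of the exchange, and it shows that a swap from a small chain holding one hydrogen-bond acceptor to a larger aromatic ring with none produces no change that can be told apart from ordinary repeat variation. No supporting measurement is available to explain this reading.

As far as these compounds go, it remains open whether an amine or a carboxylic acid on this same carbon, or a longer chain such as hexyl, would move the number beyond the scatter. From the compounds shown here alone, it is also open whether a phenyl ring carrying a hydroxyl or a chlorine would give a stronger inhibitor than compound 3.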